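A few compounds are considered here, and "the series" means these few. Any claim that something is new, unique, unknown or untested is made for them only; others in the source may bear on it.

Compound 3, `CC[C@H](C)[C@H](NC(=O)c1cccc(Cn2ccnc2)c1)C(=O)NS(=O)(=O)c1ccccc1`, and compound 1, `CC[C@H](C)[C@H](NC(=O)c1cccc(Cn2ccnc2)c1)C(=O)NNS(=O)(=O)c1ccc(OC)cc1`, share a core. In an assay on HEK293 cells for displacement of a labelled ligand from Type-2 angiotensin II receptor (Homo sapiens) (on this read-out higher numbers stand for weaker inhibition and lower numbers for stronger inhibition), compound 1 gives 9200 nM. In this assay compound 3 gives 18000 nM, which carries the higher of the two numbers, yet the gap between compound 3 and compound 1 lies within the scatter of repeated measurements, so the two cannot be told apart on this basis. A third member of the series, compound 2, `CC[C@H](C)[C@H](NC(=O)c1cccc(Cn2ccnc2)c1)C(=O)NC#N`, has in this assay only the entry "not determined" (no result reported), so no number stands for it.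

The next compound, compound 4, `CC[C@H](C)[C@H](NC(=O)c1cccc(Cn2ccnc2)c1)C(=O)NNC(=O)OC(C)(C)C`, changes the same position once more: (tert-butoxycarbonyl)amino in place of phenylsulfonyl on an amide-type nitrogen. Within the data shown here, no pair of measured compounds in this set shows what such a swap does, so the expectation rests only on the two numbers at hand, both of which describe weak binding. Compound 4 is expected to remain in the same weak range, and the step of a 1.2-fold lower number from compound 3 to compound 4 (0.08 log units; within the scatter) is estimated to be none beyond the scatter, with the direction left open. On that basis compound 4 is estimated at 15000 nM, with a likely range from 4000 nM to 60000 nM.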

Compound 4, inhibition constant: > 100000 nM
Compound 4 ended at the assay's limit; the forecaster's own chance of this, stated with the estimate: 25%; middle value at least 6.6-fold (0.82 log units) away from the limit.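

Compound 4 sits at a limit of this assay and not at a number: the limit of > 100000 nM in this assay, at which 1 of the 4 values shown sits. The earlier values at this position lay within the scatter of each other and so showed no effect of the group on the amide-type nitrogen, whereas putting (tert-butoxycarbonyl)amino in place of phenylsulfonyl gives an at least 5.5-fold higher number from compound 3 to compound 4 (0.74 log units; beyond the scatter), so the group at this position does change the read-out, toward weaker inhibition. The comparison with the other sulfonyl compound, where tert-butoxycarbonyl replaces (4-methoxyphenyl)sulfonyl on the amine nitrogen, points the same way and gives an at least 10-fold higher number from compound 1 to compound 4 (1.03 log units; beyond the scatter), so both sulfonyl compounds carry a number while the tert-butoxycarbonyl compound does not.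

Going by these compounds, as the value for compound 4 is a limit, the full size of both steps stays unknown, and the sulfonyl group and the aromatic ring leave together in each change, so the two cannot be separated. On these data alone, a methylsulfonyl group or a benzoyl group on the same nitrogen would carry only one of these two features, and what either would do remains open.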